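Dimethoxyphenyl variant in a pyrimidinone nitrile series

The compounds below may be only part of what the source reports. "The series", "measured", "known", "first", "only" and "open" are said of these compounds alone.

Of the compounds shown here, three have numbers so far. In a functional assay, with a stated time of 20 min (a higher number here means a weaker inhibitor, a lower number a stronger inhibitor), compound 1 `COc1ccc(-c2nc(SC)n(C)c(=O)c2C#N)cc1` gives 58 ug/mL. Compound 2 `CCOC(=O)c1cnn(-c2nc(-c3ccc(OC)cc3)c(C#N)c(=O)n2C)c1N` gives 59 ug/mL in this assay, and compound 3 `CSc1nc(-c2ccco2)c(C#N)c(=O)n1C` gives 68 ug/mL. Compound 2 thus sits within the usual scatter of both compound 1 and compound 3, so the three cannot be told apart on these numbers.

Compound 4 `CCOC(=O)c1cnn(-c2nc(-c3cccc(OC)c3OC)c(C#N)c(=O)n2C)c1N` is not yet measured. The change from compound 2 is 2,3-dimethoxyphenyl in place of 4-methoxyphenyl on an aromatic carbon. Among the compounds with values here, no pair of measured compounds shows this kind of change, so nothing here argues for a step beyond the scatter in either direction. The number for compound 4 in this assay is expected to be 65 ug/mL, with a range of 35 ug/mL to 120 ug/mL. The step that this estimate means, a 1.1-fold higher number from compound 2 to compound 4 (0.04 log units; within the scatter), is expected to stay within the scatter.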

Compound 4, half-maximal inhibitory concentration: 54 ug/mL
Estimate against measurement, compound 4: 1.2-fold (0.08 log units) above; low and high end bracket the measured number.
By their numbers in this assay, from the lowest: compounds 4, 1, 2 and 3 (each within the scatter of the next).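

In this assay, 2,3-dimethoxyphenyl in place of 4-methoxyphenyl on this aromatic carbon, ortho to the cyano group, gives a 1.1-fold lower number from compound 2 to compound 4 (0.04 log units; within the scatter). This is the only one-place comparison shown, and it indicates that this position accepts the dimethoxyphenyl group without a step beyond the scatter. No measurement bears on what lies behind this result.

As far as these compounds go, whether an amine or a carboxylic acid on this phenyl ring would move the number beyond the scatter remains open. From the compounds shown here alone, the effect of replacing the phenyl ring with a longer alkyl chain also remains open.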